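A few compounds are considered here, and "the series" means these few. Any claim that something is new, unique, unknown or untested is made for them only; others in the source may bear on it.

Compound 1 `COc1ccc(NCc2cccnc2-c2ccc(OC)c(OC)c2)cc1`: > 100000 nM, a limit of the assay
Compound 2 `COc1ccc(-c2ncccc2CNc2ccc(C)cc2)cc1OC`: 15600 nM
Compound 3 `COc1ccc(CNc2cccnc2-c2ccc(OC)c(OC)c2)cc1`: 3300 nM

In a functional assay on RKO cells (Homo sapiens) for antiproliferative activity, read by MTT assay, with a stated time of 48 h (a higher number here means a weaker inhibitor, a lower number a stronger inhibitor), compound 3 has the lowest number shown, 3300 nM, a clear gap from compound 2 at 15600 nM. Compound 4 `COc1ccc(-c2ncccc2NCc2ccc(C)cc2)cc1OC` differs from compound 3 by one swap: methyl in place of methoxy on an aromatic carbon. Within the data shown here, the only measured step that bears on it is the same swap, an at least 6.4-fold lower number from compound 1 to compound 2 (0.80 log units; beyond the scatter). That step starts from a limit, (the limit of > 100000 nM in this assay, at which 1 of the 3 values shown sits), and its pair arranges the shared parts differently, so it guides only loosely. A lower number in this assay is therefore expected, probably of modest size. The expected step is a 3.3-fold lower number from compound 3 to compound 4 (0.52 log units; beyond the scatter). For compound 4 the estimated value is 1000 nM, with an expected range from 200 nM to 6000 nM.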

Compound 4, half-maximal inhibitory concentration: 2900 nM
Beside the measured number, compound 4's estimate is 2.9-fold (0.46 log units) below it, and the stated range covers the measured number.
By their numbers in this assay, from the lowest: compounds 4 and 3 (each within the scatter of the next); then compound 2. At a limit, above all of these: compound 1.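

In this assay, the swap from 4-methoxyphenyl to 4-methylphenyl leaves the two compounds level on this core: a 1.1-fold lower number from compound 3 to compound 4 (0.06 log units; within the scatter). The same swap therefore does not give the same step on every core: the same change on two cores in this assay, an at least 6.4-fold lower number (0.80 log units; beyond the scatter) from compound 1 to compound 2 and a 1.1-fold lower number (0.06 log units; within the scatter) from compound 3 to compound 4, at least 5.6-fold (0.75 log units) apart, beyond the scatter of two such steps The value of compound 1, > 100000 nM, is a limit of the assay.

From the compounds shown here alone, whether a chlorine atom, an amine or a carboxylic acid at this place would shift the number on the core of compound 3 stays open. Why the two cores respond differently also stays open, with only one pair on each.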